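From (trifluoromethyl)sulfanyl to trifluoromethyl: compound 2 to compound 3

The compounds below may be only part of what the source reports. "The series", "measured", "known", "first", "only" and "open" are said of these compounds alone.

In a functional assay on MDA-MB-231 cells (Homo sapiens) for inhibition, read by MTT assay, with a stated time of 72 h (a lower number here means a stronger inhibitor, a higher number a weaker inhibitor), compound 1 (`NS(=O)(=O)c1ccc2c(c1)C(=O)C(=O)N2Cc1cccc(C(F)(F)F)c1`) gives 14200 nM and compound 2 (`NS(=O)(=O)c1ccc2c(c1)C(=O)C(=O)N2Cc1ccc(SC(F)(F)F)cc1`) gives 6900 nM. Compound 2 therefore holds the lower of the two numbers, and its gap to compound 1 lies beyond the usual scatter. Compound 3 (`NS(=O)(=O)c1ccc2c(c1)C(=O)C(=O)N2Cc1ccc(C(F)(F)F)cc1`) has trifluoromethyl in place of (trifluoromethyl)sulfanyl on an aromatic carbon, para to a large group: trifluoromethyl in place of (trifluoromethyl)sulfanyl on an aromatic carbon. Among the compounds with values here, no measured pair shows this change on its own, so its size cannot be read directly from the data. Within the data shown here, the only other reference is compound 1 at 14200 nM, so a modest rise in the number is expected, possibly one within the scatter. The expected change is a 1.5-fold higher number from compound 2 to compound 3 (0.18 log units; within the scatter). For compound 3 the estimated value is 10500 nM, with an expected range of 5000 nM to 20000 nM.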

Compound 3, half-maximal inhibitory concentration: 27100 nM
For compound 3 the middle estimate is 2.6-fold (0.41 log units) below the measured one; the whole stated range lies below it.
By their numbers in this assay, from the lowest: compound 2; then compounds 1 and 3 (each within the scatter of the next).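

In this assay, within the data shown here, trifluoromethyl in place of (trifluoromethyl)sulfanyl on an aromatic carbon, para to a large group, gives a 3.9-fold higher number from compound 2 to compound 3 (0.59 log units; beyond the scatter); this is the first change read on its own, and it shows that this position responds to the swap. Compound 2 now holds the lowest number of the three, with both of the others beyond the scatter from it. Compound 1 and compound 3 both carry trifluoromethyl and lie within the scatter of each other, and no measurement on hand accounts for the step.

From the compounds shown here alone, it remains open whether the sulfur-linked group itself matters at this place, or whether a methoxy group, a chlorine, a nitrile or an amine there would read the same way. A single step on the shared core also cannot show whether the change behaves alike on other members of the series.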